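Benzoxaborole chalcones in a fibroblast viability assay

The source may report more compounds than this note shows. Statements on the series, on what has been measured and on what is new or still open speak of the compounds shown alone.

The measured compounds are:
compound 1, `O=C(/C=C/c1ccc2c(c1)B(O)OC2)c1ccccc1`, 19100 nM
compound 2, `O=C(/C=C/c1ccc2c(c1)B(O)OC2)c1cccc(F)c1`, 26700 nM
compound 3, `COCOc1cccc(C(=O)/C=C/c2ccc3c(c2)B(O)OC3)c1`, 33200 nM

In a toxicity assay on WI-38 cells (Homo sapiens) for cytotoxicity, read by MTT assay, with a stated time of 48 h (on this read-out higher numbers stand for weaker inhibition and lower numbers for stronger inhibition), compound 1 gives 19100 nM, the lowest of the three numbers, though all three lie within the scatter of one another: the step of a 1.4-fold higher number from compound 1 to compound 2 (0.15 log units; within the scatter) and the step of a 1.7-fold higher number from compound 1 to compound 3 (0.24 log units; within the scatter) are both small, as is a 1.2-fold higher number from compound 2 to compound 3 (0.09 log units; within the scatter). Compound 4, `O=C(O)c1ccc(C(=O)/C=C/c2ccc3c(c2)B(O)OC3)cc1`, differs from compound 1 by carboxy in place of hydrogen on an aromatic carbon. Within the data shown here, no measured step introduces a carboxy group; the steps that bear on it are the substitutions on the same ring of compound 1, namely a 1.4-fold higher number from compound 1 to compound 2 (0.15 log units; within the scatter) and a 1.7-fold higher number from compound 1 to compound 3 (0.24 log units; within the scatter), and neither moved the read-out beyond the scatter. Compound 4 is therefore expected to stay close to compound 1, with a step of a 1.5-fold higher number from compound 1 to compound 4 (0.17 log units; within the scatter) in this assay, and its estimated value is 28000 nM with a range from 12000 nM to 65000 nM.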

Compound 4, half-maximal inhibitory concentration: > 100000 nM
Compound 4: only a limit was reported; the forecaster's own chance of this, stated with the estimate: 10%; at least 3.5-fold (0.55 log units) between middle value and limit.
By their numbers in this assay, from the lowest: compounds 1, 2 and 3 (each within the scatter of the next). At a limit, above all of these: compound 4.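

In this assay compound 4 gives only a limit of the assay and not a number, > 100000 nM: the limit of > 100000 nM in this assay, at which 1 of the 4 values shown sits. Carboxy in place of hydrogen, on an aromatic carbon para to a large group, gives an at least 5.2-fold higher number from compound 1 to compound 4 (0.71 log units; beyond the scatter), the only step here printed as beyond the scatter, while the earlier changes on this ring stayed within it, with a 1.4-fold higher number from compound 1 to compound 2 (0.15 log units; within the scatter) and a 1.7-fold higher number from compound 1 to compound 3 (0.24 log units; within the scatter). The ring is therefore not indifferent to every substituent in this assay, as those two earlier steps alone might have suggested.

As far as these compounds go, how far the true value of compound 4 lies past its limit remains open. So does whether the step belongs to carboxy itself or to its place, a question that an amine or a methyl ester at this same place, or a carboxylic acid where compound 2 carries fluoro, would address.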